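This account rests on a few compounds, and the source may have more. Where it says the series, first, only, none or still open, it means among the compounds named here.

Working notes on the series. Compound 1 `N#Cc1ccc(Cn2cncc2CNc2ccc(C(=O)Nc3cccc([N+](=O)[O-])c3)c(-c3ccccc3)c2)cc1` carries a 3-nitrophenyl group on the amide-type nitrogen. In a functional assay on NIH3T3 cells (Mus musculus) (a lower number here means that less compound is needed, a higher number that more compound is needed for the effect), compound 1 gives only a limit of the assay, > 10 uM. Compound 2 `CC(C)NC(=O)c1ccc(NCc2cncn2Cc2ccc(C#N)cc2)cc1-c1ccccc1` has isopropyl in place of 3-nitrophenyl on the amide-type nitrogen. In this assay compound 2 likewise gives only a limit, > 10 uM. The step that the two limits leave unreadable from compound 1 to compound 2 therefore has no readable size, because both ends sit at the limit of > 10 uM in this assay, at which 2 of the 2 values shown sit. Compound 2 thus stands at the limit in this assay, with no numerical value to anchor it.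

Compound 3 `N#Cc1ccc(Cn2cncc2CNc2ccc(C(=O)NCc3ccccc3)c(-c3ccccc3)c2)cc1` is the next member. The change is benzyl in place of isopropyl on an amide-type nitrogen. Among the measured compounds shown here, the only measured step that touches the amide-type nitrogen, a step that the two limits leave unreadable from compound 1 to compound 2, is unreadable, so it offers no size to carry forward, and both compounds measured so far sit at the limit. The expectation for compound 3 is therefore no step beyond the scatter, a step that the limit leaves unreadable from compound 2 to compound 3, and most probably another limit rather than a number. Compound 3 is estimated in this assay at 15 uM, with a range from 5 uM to 50 uM.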

Compound 3, concentration for half-maximal effect: > 10 uM
Compound 3: no number, only a limit (the forecaster's own chance of this, stated with the estimate: 75%); the middle value lies beyond the limit too.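

In this assay compound 3 gives only a limit, > 10 uM, so no step among compound 1, compound 2 and compound 3 can be read: the limit of > 10 uM in this assay, at which 3 of the 3 values shown sit.

The compounds shown leave open whether any group on the amide-type nitrogen gives a numerical value in this assay, and how these three compounds compare.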